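This account rests on a few compounds, and the source may have more. Where it says the series, first, only, none or still open, it means among the compounds named here.

Compound 1 `COc1cc2c(Oc3ccc(NC(=O)c4nn(-c5ccccc5)c(=O)c5ccccc45)cc3F)ccnc2cc1OCCCN1CCN(C)CC1` and compound 2 `COc1cc2c(Oc3ccc(NC(=O)c4nn(-c5ccc(Br)cc5)c(=O)c5ccccc45)cc3F)ccnc2cc1OCCCN1CCN(C)CC1` share one core and differ only at one aromatic carbon. In a functional assay on NCI-H460 cells (Homo sapiens) for cytotoxicity, read by MTT assay, with a stated time of 72 h (a higher number here means a weaker inhibitor, a lower number a stronger inhibitor), compound 1 gives 450 nM, and in this assay compound 2 gives 250 nM. The step of a 1.8-fold lower number from compound 1 to compound 2 (0.26 log units; within the scatter) is the only one measured, so compound 2 holds the lowest of the two numbers, though its gap to compound 1 is within the scatter. Compound 3 `COc1cc2c(Oc3ccc(NC(=O)c4nn(-c5ccc(Br)cc5)c(=O)c5ccccc45)cc3F)ccnc2cc1OCCCN1CCC(C)CC1` is compound 2 with 4-methylpiperidin-1-yl in place of 4-methylpiperazin-1-yl on a saturated chain carbon, three bonds along the chain from an oxygen on an aromatic ring. Going by the values given here, no measured pair shows this change: the step from compound 1 to compound 2 concerns a different part of the molecule and gives no guide to the chain end. The expectation in this assay is therefore no step beyond the scatter, which is what a 1.4-fold higher number from compound 2 to compound 3 (0.15 log units; within the scatter) means. Compound 3 is expected to give 350 nM in this assay, with an estimated range from 150 nM to 900 nM.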

Compound 3, half-maximal inhibitory concentration: 350 nM
For compound 3 middle estimate and measured number coincide at the digits printed, within the range that was stated.
By their numbers in this assay, from the lowest: compounds 2, 3 and 1 (each within the scatter of the next).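

In this assay, going by these compounds alone, the chain end is probed for the first time, and a 1.4-fold higher number from compound 2 to compound 3 (0.15 log units; within the scatter) is what it shows when 4-methylpiperazin-1-yl gives way to 4-methylpiperidin-1-yl. At this position, on a saturated chain carbon, a ring with one hetero atom and one hydrogen-bond acceptor therefore reads the same, within the scatter, as a ring with two of each, at least on the bromo-bearing core of compound 2. Nothing available accounts for this outcome.

As far as these compounds go, whether the same swap would read alike on the core of compound 1, without the bromo, remains open. So does what a morpholin-4-yl group, a dimethylamino group or a chain longer than propyl would give at this chain end.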